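A few compounds are considered here, and "the series" means these few. Any claim that something is new, unique, unknown or untested is made for them only; others in the source may bear on it.

Of the compounds shown here, two sharing one core have been tested in a functional assay on MCF7 cells (Homo sapiens) for cytotoxicity, read by MTT assay, with a stated time of 48 h; a lower number here means a stronger inhibitor, a higher number a weaker inhibitor. Compound 1 `CCN(CC)c1ccc2cc(C(=O)c3ccc(N4CCN(C(=O)CN5CCN(C(=O)/C=C/c6ccccc6)CC5)CC4)cc3)oc2c1` gives 13400 nM. Compound 2 `CCN(CC)c1ccc2cc(C(=O)c3ccc(N4CCN(C(=O)CN5CCN(Cc6ccc(F)c(F)c6)CC5)CC4)cc3)oc2c1` gives 9220 nM, and the step of a 1.5-fold lower number from compound 1 to compound 2 (0.16 log units; within the scatter) lies within the scatter, so the two numbers cannot be told apart. Compound 3 `CCN(CC)c1ccc2cc(C(=O)c3ccc(N4CCN(C(=O)CN5CCN(Cc6ccc(C(F)(F)F)cc6)CC5)CC4)cc3)oc2c1` has not been measured; it differs from compound 2 by 4-(trifluoromethyl)phenyl in place of 3,4-difluorophenyl on a saturated chain carbon bound to an amine nitrogen in a ring. Among the compounds with values here, no measured step swaps one such benzyl group for another; the single known step replaces a whole group on that ring nitrogen and stays within the scatter, so no step beyond the scatter is expected here. Compound 3 is therefore estimated at 9000 nM, between 4000 nM and 25000 nM. The expected step is a 1.0-fold lower number from compound 2 to compound 3 (0.01 log units; within the scatter).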

Compound 3, half-maximal inhibitory concentration: 18200 nM
Compound 3: middle estimate off by 2.0-fold (0.31 log units), on the low side; measured number inside the range.
By their numbers in this assay, from the lowest: compounds 2, 1 and 3 (each within the scatter of the next).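

In this assay, exchanging 3,4-difluorobenzyl for 4-(trifluoromethyl)benzyl on this ring nitrogen gives a 2.0-fold higher number from compound 2 to compound 3 (0.30 log units; within the scatter), a change within the benzyl group itself that the earlier step did not cover. Replacing the (2-phenylethenyl)carbonyl group with 4-(trifluoromethyl)benzyl gives a 1.4-fold higher number from compound 1 to compound 3 (0.13 log units; within the scatter), so the three groups at this position cannot be told apart in this assay. Nothing available here accounts for these numbers. Still open, on these data alone, is whether a benzyl group carrying an amine or a carboxylic acid, or a longer chain on that ring nitrogen, would give a step beyond the scatter.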